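The compounds below may be only part of what the source reports. "The series", "measured", "known", "first", "only" and "open" are said of these compounds alone.

Measured so far:
Compound 1 `Cc1ccc(-c2c3c(nc(C)c2C(OC(C)(C)C)C(=O)O)CCN(S(C)(=O)=O)C3)cc1` — in an ADME assay on MT2 cells (Homo sapiens) for cytotoxicity, read by XTT assay, with a stated time of 4 days (on this read-out lower numbers stand for higher toxicity in this test and higher numbers for lower toxicity in this test), compound 1 gives > 40000 nM, which is a limit of the assay rather than a number.
Compound 2 `Cc1cccc(CCCN2CCc3nc(C)c([C@H](OC(C)(C)C)C(=O)O)c(-c4cc(F)c5c(c4C)CCCO5)c3C2)c1` — compound 2 gives > 40000 nM, again a limit.
Compound 3 `Cc1nc2c(c(-c3cc(F)c4c(c3C)CCCO4)c1[C@H](OC(C)(C)C)C(=O)O)CN(CCCc1ccccc1)CC2` — compound 3 gives > 40000 nM, also a limit.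

Compound 1 therefore stands only at a limit, as do the two other values shown. For the measured compounds named here, the one step between measured compounds, a step that the two limits leave unreadable from compound 2 to compound 3, is unreadable because both ends sit at the limit of > 40000 nM in this assay, at which 3 of the 3 values shown sit. Compound 4 `Cc1ccc(-c2c3c(nc(C)c2C(OC(C)(C)C)C(=O)O)CCN(c2cccc(-c4ccccc4)c2)C3)cc1` differs from compound 1 by 3-phenylphenyl in place of methylsulfonyl on an amine nitrogen in a ring. Going by the values given here, no measured step resembles this change, so nothing here reads on its size or direction. He expects compound 4 to give 25000 nM, within 6000 nM to 60000 nM, an estimated step of an at least 1.6-fold lower number from compound 1 to compound 4 (0.20 log units; that floor lies within the scatter) from the limit seen for compound 1.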

Compound 4, half-maximal cytotoxic concentration: > 40000 nM
Compound 4 ended at the assay's limit; the forecaster's own chance of this, stated with the estimate: 50%; at least 1.6-fold (0.20 log units) between middle value and limit.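

No step can be read from compound 1 to compound 4 in this assay, because both stand at a limit and not at a number: the limit of > 40000 nM in this assay, at which 4 of the 4 values shown sit. The compounds shown leave open what number any of them would give, and which change, if any, moves this read-out.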